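Swapping Cyclopropyl for an Acetylpyrrolidinyl Group

The compounds below may be only part of what the source reports. "The series", "measured", "known", "first", "only" and "open" are said of these compounds alone.

compound 1 `CC(C)N(C)c1ccc2cc(NC(=O)CCc3ccc(C(F)(F)F)cc3)cnc2n1`: 365 nM
compound 2 `CC(C)N(C)c1nc2ccc(NC(=O)CCc3ccc(C(F)(F)F)cc3)cc2s1`: > 750 nM
compound 3 `CN(c1nc2ccc(NC(=O)CCc3ccc(C(F)(F)F)cc3)cc2[nH]1)C1CC1`: 24 nM

Of the compounds shown here, three have been tested in an assay on CHO-K1 cells for displacement of a labelled ligand from melanin-concentrating hormone receptor 1 (Homo sapiens), read by scintillation counting; on this read-out lower numbers stand for stronger inhibition and higher numbers for weaker inhibition. Compound 1 gives 365 nM. For compound 2 the assay reports only a limit, > 750 nM, which is the limit of > 750 nM in this assay, at which 1 of the 3 values shown sits. Compound 3 gives 24 nM, the lowest of the two numbers available, and its gap to compound 1 lies beyond the usual scatter. No two of these compounds differ in a single place, so none of them shows how a change at the amino nitrogen plays out.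

Compound 4 `CC(=O)N1CCC(N(C)c2nc3ccc(NC(=O)CCc4ccc(C(F)(F)F)cc4)cc3[nH]2)C1` has not yet been measured. It differs from compound 3 in one place: 1-acetylpyrrolidin-3-yl in place of cyclopropyl on a nitrogen on an aromatic ring. Among the measured compounds shown here, with no measured pair for this change, the direction can only be guessed; a modest loss is expected, with the step estimated as a 2.1-fold higher number from compound 3 to compound 4 (0.32 log units; beyond the scatter). Compound 4 is thus expected to give about 50 nM in this assay, most likely between 15 nM and 200 nM.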

Compound 4, half-maximal inhibitory concentration: 30 nM
Compound 4: the middle estimate sits 1.7-fold (0.22 log units) above what was measured, within the range that was stated.
By their numbers in this assay, from the lowest: compounds 3 and 4 (each within the scatter of the next); then compound 1. At a limit, above all of these: compound 2.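

Exchanging the cyclopropyl group for 1-acetylpyrrolidin-3-yl gives a 1.3-fold higher number from compound 3 to compound 4 (0.10 log units; within the scatter) in this assay and this is the only pair shown that differs in one place. At this position, a group of 8 heavy atoms with a five-membered ring, a ring nitrogen and a hydrogen-bond acceptor therefore reads the same, within the scatter, as a three-membered carbon ring of 3 heavy atoms. Nothing measured here explains why the two groups read alike.

Still open, as far as these compounds go, is whether a free amine on the pyrrolidine ring, or a carboxylic acid in place of the acetyl group, would also hold the read-out at this level. The compounds also leave open whether 1-acetylpyrrolidin-3-yl would behave the same way on the core of compound 1.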